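This account rests on a few compounds, and the source may have more. Where it says the series, first, only, none or still open, it means among the compounds named here.

Of the compounds shown here, three have so far been tested in a toxicity assay on Huh-7.5 cells (Homo sapiens) for inhibition, read by MTT assay, with a stated time of 96 h; a higher number here means that more compound is tolerated, a lower number that less compound is tolerated. Compound 1 `CCC(=O)Nc1cc(C(=O)Nc2ccc(CN3CCN(C)CC3)c(C(F)(F)F)c2)ccc1OC` gives 35300 nM, compound 2 `CC(C)Oc1ccc(C(=O)Nc2ccc(N(C)C)cc2)cc1[N+](=O)[O-]` gives 50000 nM, and compound 3 `COc1ccc(C(=O)Nc2cc(OC)c(OC)c(OC)c2)cc1NC(=O)C(C)Br` gives 15000 nM. Compound 2 stands at the highest of these three numbers, yet its gap to compound 1 lies within the usual scatter of the measurement, so the two cannot be placed in any order. Its gap to compound 3 lies beyond the scatter.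

Compound 4 `CC(C)Oc1ccc(C(=O)Nc2ccc(N(C)C)cc2)cc1NC(=O)C(C)Br` has not yet been measured in this assay. It differs from compound 2 in a single place: ((1-bromoethyl)carbonyl)amino in place of nitro on an aromatic carbon. For the measured compounds named here, no measured pair isolates this exact change, so its effect is uncertain. Compound 3 carries the same ((1-bromoethyl)carbonyl)amino group on a different core and gives 15000 nM, which suggests that tolerance may fall somewhat. The expected step is a 2.3-fold lower number from compound 2 to compound 4 (0.36 log units; beyond the scatter), a moderate drop. Compound 4 is therefore estimated at 22000 nM, with a range from 9000 nM to 50000 nM.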

Compound 4, half-maximal cytotoxic concentration: 7900 nM
Compound 4: the middle estimate sits 2.8-fold (0.44 log units) above what was measured; measured number outside the range, below it.
By their numbers in this assay, from the lowest: compounds 4 and 3 (each within the scatter of the next); then compounds 1 and 2 (each within the scatter of the next).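

In this assay, placing ((1-bromoethyl)carbonyl)amino in place of nitro on this aromatic carbon, ortho to an isopropoxy group, gives a 6.3-fold lower number from compound 2 to compound 4 (0.80 log units; beyond the scatter). For the compounds shown here, this is the first comparison here in which only one place on the molecule changes, so the drop, which lies beyond the usual scatter, can be tied to this exchange at this position. The earlier compounds shown here differ from one another in more than one place and could not show this. Nothing measured here bears on the reason for this drop.

From the compounds shown here alone, it remains open whether the bromine matters, since a free amine or an acetylamino group at this same position would separate the bromine from the rest of the new group. Going by these compounds, it is also open whether the same exchange lowers the number to a similar extent on a different core.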